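The source may hold more compounds than are shown below. What is called first, only, known or untested is meant among the compounds shown, and "the series" means these compounds.

Compound 1 `O=S(=O)(/C=C/c1ccccn1)c1cccc(Cl)c1` is the weaker of the two measured compounds in an assay on U2OS cells for activation of nuclear factor erythroid 2-related factor 2 (Homo sapiens), read by beta-arrestin recruitment, with a stated time of 6 h (on this read-out lower numbers stand for an effect already at smaller amounts and higher numbers for an effect only at larger amounts of compound), where compound 1 gives 1430 nM. Its partner compound 2 `O=S(=O)(/C=C/c1ncccc1F)c1cccc(Cl)c1`, in this assay, gives 198 nM; the change between them was a 7.2-fold lower number from compound 1 to compound 2 (0.86 log units; beyond the scatter). Compound 3 `O=S(=O)(/C=C/c1cccc(Cl)n1)c1cccc(Cl)c1` has not yet been measured. It differs from compound 1 by chloro in place of hydrogen on an aromatic carbon, the new group sitting next to the ring nitrogen, meta to a large group. Going by the values given here, the only measured step that bears on this is the one from compound 1 to compound 2, where a small halogen entering the same ring, though at a different place, lowered the number in this assay by a modest amount. A similar direction, with a smaller and less certain size, is expected here, so for compound 3 the step is estimated as a 2.9-fold lower number from compound 1 to compound 3 (0.46 log units; beyond the scatter). Compound 3 is therefore expected to give about 500 nM in this assay, within a range of 150 nM to 1800 nM.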

Compound 3, half-maximal effective concentration: 1070 nM
The estimate for compound 3 lay 2.1-fold (0.33 log units) below the measured number, within the range that was stated.
By their numbers in this assay, from the lowest: compound 2; then compounds 3 and 1 (each within the scatter of the next).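

In this assay, the step of chloro in place of hydrogen next to the ring nitrogen is a 1.3-fold lower number from compound 1 to compound 3 (0.13 log units; within the scatter), so at this position compound 3 cannot be told apart from compound 1. A halogen on this ring therefore does not always bring a clear drop like a 7.2-fold lower number from compound 1 to compound 2 (0.86 log units; beyond the scatter), although that step differs in both the halogen and its place, and these two effects cannot be separated. No measurement shown offers an explanation for the result at this position.

As far as these compounds go, it remains open whether a fluoro, methyl or methoxy group next to the ring nitrogen would match chloro there. From the compounds shown here alone, it is also open whether chloro at the place that fluoro holds in compound 2 would give a number like that of compound 2.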